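This account rests on a few compounds, and the source may have more. Where it says the series, first, only, none or still open, it means among the compounds named here.

Measured compounds:
compound 1 `O=C(CCc1cccc2c1B(O)OC2)Nc1ccccc1` gives 200 nM in a functional assay on SK-OV-3 cells (Homo sapiens) for antiproliferative activity, read by MTT assay, with a stated time of 72 h; a lower number here means a stronger inhibitor, a higher number a weaker inhibitor
compound 2 `C#Cc1ccccc1NC(=O)CCc1cccc2c1B(O)OC2` gives 820 nM in this assay

Compound 1 holds the lowest of the two numbers; compound 2 stands nearest, with a 4.1-fold higher number from compound 1 to compound 2 (0.61 log units; beyond the scatter). Compound 3 `O=C(CCc1cccc2c1B(O)OC2)Nc1ccc(-c2ccccc2)cc1` is not yet measured. It differs from compound 1 by phenyl in place of hydrogen on an aromatic carbon. Within the data shown here, the one step that bears on it, the addition of a carbon group on the same ring of compound 1, gave a 4.1-fold higher number from compound 1 to compound 2 (0.61 log units; beyond the scatter), so a rise beyond the scatter is expected for compound 3 too. The estimate for compound 3 is 550 nM, between 180 nM and 1800 nM, meaning a 2.8-fold higher number from compound 1 to compound 3 (0.44 log units; beyond the scatter).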

Compound 3, half-maximal inhibitory concentration: 48000 nM
Beside the measured number, compound 3's estimate is 87-fold (1.94 log units) below it, outside the stated range (above it).
By their numbers in this assay, from the lowest: compound 1; then compound 2; then compound 3.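

In this assay, phenyl on the aromatic carbon para to a large group gives a 240-fold higher number from compound 1 to compound 3 (2.38 log units; beyond the scatter), a large rise against the modest 4.1-fold higher number from compound 1 to compound 2 (0.61 log units; beyond the scatter) seen with ethynyl. Carbon groups on this ring therefore do not all act alike, but with both group and place differing, the two steps cannot separate their contributions. Nothing available explains the size of the rise.

Still open, from the compounds shown here alone, is whether a smaller group at this position, such as methyl or an amine, stays close to compound 1. Also open, going by these compounds, is whether a carboxylic acid on the added phenyl changes the outcome.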